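A few compounds are considered here, and "the series" means these few. Any claim that something is new, unique, unknown or untested is made for them only; others in the source may bear on it.

Working notes on the series. All three measured compounds share one core and differ only in the group on an amine nitrogen; the numbers come from a functional assay on ECa-109 cells for inhibition, with ECa-109 cell line (Homo sapiens) as the target, read by sulforhodamine B assay; a lower number here means a stronger inhibitor, a higher number a weaker inhibitor.

Compound 1 `COc1cccc(NC2=CC(=O)c3c(nc4n3[C@H]3OC[C@@H](O)[C@H]3OC4)C2=O)c1` gives 3340 nM in this assay. Compound 3 `O=C1C(Nc2ccccc2F)=CC(=O)c2c1nc1n2[C@H]2OC[C@@H](O)[C@H]2OC1` gives 2660 nM in this assay, and the step of a 1.3-fold lower number from compound 1 to compound 3 (0.10 log units; within the scatter) stays within the scatter. Compound 2 `O=C1C(NC2CCCC2)=CC(=O)c2c1nc1n2[C@H]2OC[C@@H](O)[C@H]2OC1` is reported in this assay only as a limit, > 16000 nM, at the limit of > 16000 nM in this assay, at which 1 of the 3 values shown sits. Against that limit, the step of an at least 4.7-fold higher number from compound 1 to compound 2 (0.68 log units; beyond the scatter) and the step of an at least 6.0-fold lower number from compound 2 to compound 3 (0.77 log units; beyond the scatter) are both beyond the scatter, so the two aryl groups on the amine nitrogen sit at lower numbers than the cyclopentyl group. Of the two numbers shown, compound 3 has the lower one, but its gap to compound 1 is within the scatter, so no order between them can be read.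

Compound 4 `CCc1ccc(NC2=CC(=O)c3c(nc4n3[C@H]3OC[C@@H](O)[C@H]3OC4)C2=O)cc1` is not yet measured. It differs from compound 3 by 4-ethylphenyl in place of 2-fluorophenyl on an amine nitrogen. Going by the values given here, the only measured step of the same kind, one aryl group for another on the amine nitrogen, is a 1.3-fold lower number from compound 1 to compound 3 (0.10 log units; within the scatter), which stayed within the scatter; the steps through compound 2 concern a cyclopentyl group and do not bear on an aryl-to-aryl swap. For compound 4 the expected step is therefore a 1.1-fold higher number from compound 3 to compound 4 (0.05 log units; within the scatter), a change not beyond the scatter in either direction. Compound 4 is thus estimated at 3000 nM, with a range from 1200 nM to 7500 nM.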

Compound 4, half-maximal inhibitory concentration: > 4000 nM
Compound 4 ended at the assay's limit; the forecaster's own chance of this, stated with the estimate: 5%; at least 1.3-fold (0.12 log units) between middle value and limit.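

In this assay compound 4 stands only as a limit: the limit of > 4000 nM in this assay, at which 1 of the 4 values shown sits.

The floors of the two readable steps, an at least 1.5-fold higher number from compound 3 to compound 4 (0.17 log units; that floor lies within the scatter) and an at least 1.1-fold higher number from compound 1 to compound 4 (0.07 log units; that floor lies within the scatter), both lie within the scatter, so no order can be read between 4-ethylphenyl and either of the two earlier aryl groups on the amine nitrogen. The step between compound 2 and compound 4 cannot be read, since both values are limits, so the lower numbers of 3-methoxyphenyl and 2-fluorophenyl relative to cyclopentyl do not carry over to 4-ethylphenyl, and an aryl group on this nitrogen is no longer shown to be enough for a number under the limit.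

Open, from the compounds shown here alone, is whether compound 4 lies close to compound 1 and compound 3 or far from them, which a limit cannot settle. Also open, going by these compounds, is whether the change in the result goes with the ethyl group or with the loss of the fluorine, a question that a 4-fluorophenyl group, a 2-ethylphenyl group or an unsubstituted phenyl group on the same nitrogen would address.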